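The compounds below may be only part of what the source reports. "The series", "measured", "known", "first", "only" and "open" are said of these compounds alone.

Measured in a functional assay on MCF7 cells (Homo sapiens) for cytotoxicity, read by sulforhodamine B assay, with a stated time of 48 h; a lower number here means a stronger inhibitor, a higher number a weaker inhibitor:
- compound 1 `N#Cc1c(-c2ccc(Cl)cc2)cc(-c2ccc(Cl)cc2)n([C@@H]2O[C@H](COC(=O)c3ccccc3)[C@@H](OC(=O)c3ccccc3)[C@H]2OC(=O)c2ccccc2)c1=O`: 5.9 ug/mL
- compound 2 `N#CCn1c(-c2ccc(Cl)cc2)cc(-c2ccc(Cl)cc2)c(C#N)c1=O`: "not active" (no number reported)
- compound 3 `CC(=O)OC[C@H]1O[C@@H](n2c(-c3ccc(Cl)cc3)cc(-c3ccc(Cl)cc3)c(C#N)c2=O)[C@H](OC(C)=O)[C@@H](OC(C)=O)[C@@H]1OC(C)=O`: 6.3 ug/mL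

Compound 2 has no place on the numerical scale: in this assay compound 2 was recorded as "not active" (no number reported). Compound 1 and compound 3 both returned numbers, and these lie within the scatter of each other. The data do not show what concentration separates a numbered result from the verdict given for compound 2.

Compound 4 `C#CCn1c(-c2ccc(Cl)cc2)cc(-c2ccc(Cl)cc2)c(C#N)c1=O` has not yet been measured. The structural change is ethynyl in place of cyano on a saturated chain carbon bound to an aromatic nitrogen, or cyanomethyl to propargyl. Going by the values given here, no measured pair shows what this swap does. Because compound 2 gave "not active" (no number reported), no step beyond the scatter is expected in this assay, and a result without a number is quite possible. If a number is obtained, compound 4 is expected at about 15 ug/mL, with an estimated range of 5 ug/mL to 50 ug/mL.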

Compound 4, half-maximal inhibitory concentration: 16.7 ug/mL
For compound 4 the middle estimate is 1.1-fold (0.05 log units) below the measured one; the range from low to high includes it.
By their numbers in this assay, from the lowest: compounds 1 and 3 (each within the scatter of the next); then compound 4.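

Going by these compounds alone, compound 2 has no number in this assay while compound 4 gives 16.7 ug/mL, and no step from cyanomethyl to propargyl can be read between them. How far this swap moves the value stays open, and nothing measured here offers an explanation for the result.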